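This account rests on a few compounds, and the source may have more. Where it says the series, first, only, none or still open, it means among the compounds named here.

Measured so far:
compound 1 `CCS(=O)(=O)Nc1cc(-c2ccc3ncnc(Nc4ccc(OC)cc4)c3c2)cnc1OC` gives 3490 nM
compound 2 `CCS(=O)(=O)Nc1cc(-c2ccc3ncnc(Nc4ccc(OC)c(Cl)c4)c3c2)cnc1OC` gives 5620 nM

Both numbers come from a functional assay on HCT-116 cells (Homo sapiens) for cytotoxicity, read by sulforhodamine B assay, with a stated time of 72 h; on this read-out higher numbers stand for weaker inhibition and lower numbers for stronger inhibition. Among the measured compounds shown here, compound 2 stands highest of the two, and the only step on record, a 1.6-fold higher number from compound 1 to compound 2 (0.21 log units; within the scatter), lies within the scatter. Compound 3 `CCS(=O)(=O)Nc1cc(-c2ccc3ncnc(Nc4ccc(F)c(C(=O)OC)c4)c3c2)cnc1OC` differs from compound 2 by 4-fluoro-3-(methoxycarbonyl)phenyl in place of 3-chloro-4-methoxyphenyl on a nitrogen on an aromatic ring. For the measured compounds named here, the one measured step concerns only a chloro on that ring and says nothing about removing the methoxy or adding the methoxycarbonyl and fluoro; no step beyond the scatter is therefore expected in this assay, with wide uncertainty. Compound 3 is expected at 6000 nM, range 1800 nM to 20000 nM, an expected step of a 1.1-fold higher number from compound 2 to compound 3 (0.03 log units; within the scatter).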

Compound 3, half-maximal inhibitory concentration: 2360 nM
The estimate for compound 3 lay 2.5-fold (0.41 log units) above the measured number, within the range that was stated.
By their numbers in this assay, from the lowest: compounds 3, 1 and 2 (each within the scatter of the next, the first and the last beyond it).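

Among the compounds shown here, at the nitrogen on an aromatic ring, 4-fluoro-3-(methoxycarbonyl)phenyl gives the first step beyond the scatter in this assay (a 2.4-fold lower number from compound 2 to compound 3 (0.38 log units; beyond the scatter)). Set against the 4-methoxyphenyl group, the same substituent shows no such separation (a 1.5-fold lower number from compound 1 to compound 3 (0.17 log units; within the scatter)), so the change reads only against the 3-chloro-4-methoxyphenyl group. No measurement at hand accounts for this step.

On these data alone, the fluoro and the methoxycarbonyl enter together, and which of them carries the step stays open. Also open, as far as these compounds go, is how a carboxylic acid or an amide in place of the methoxycarbonyl would read in this assay.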